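Swapping Chloro for Nitro on Two Sulfone Cores

The source may hold more compounds than are shown below. What is called first, only, known or untested is meant among the compounds shown, and "the series" means these compounds.

Three compounds have been measured in a functional assay on DU-145 cells (Homo sapiens) for antiproliferative activity, read by trypan blue exclusion; a lower number here means a stronger inhibitor, a higher number a weaker inhibitor:

Compound 1, `COc1cc(OC)c(/C=C/S(=O)(=O)Cc2ccc(Cl)cc2)c(OC)c1`, gives 7500 nM.
Compound 2, `COc1cc(OC)c(/C=C/S(=O)(=O)Cc2ccc([N+](=O)[O-])cc2)c(OC)c1`, gives 15000 nM.
Compound 3, `COc1ccc(CS(=O)(=O)/C=C/c2ccc(Cl)cc2)cc1`, gives 2500 nM.

Compound 2 differs from compound 1 by nitro in place of chloro on an aromatic carbon, and that step is a 2.0-fold higher number from compound 1 to compound 2 (0.30 log units; within the scatter). Compound 3 stands on a different core, and the difference between the two cores is not broken down here. Compound 4, `COc1ccc(CS(=O)(=O)/C=C/c2ccc([N+](=O)[O-])cc2)cc1`, is compound 3 carrying the same change, (nitro in place of chloro on an aromatic carbon), at the same place. For the measured compounds named here, the step of a 2.0-fold higher number from compound 3 to compound 4 (0.30 log units; within the scatter) is expected to be small, because a 2.0-fold higher number from compound 1 to compound 2 (0.30 log units; within the scatter) was small on the other core, and only one earlier example supports this expectation. For compound 4 the estimate in this assay is 5000 nM, expected to lie between 2000 nM and 12000 nM.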

Compound 4, half-maximal inhibitory concentration: 7500 nM
Estimate against measurement, compound 4: 1.5-fold (0.18 log units) below, and the stated range covers the measured number.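

In this assay, nitro in place of chloro gives a 3.0-fold higher number from compound 3 to compound 4 (0.48 log units; beyond the scatter) and so lies beyond the scatter on this core, though the step remains modest. Set beside the step on the core of compound 1, it does not differ by more than the scatter, so the change carries over between these two cores with much the same size: the same change on two cores in this assay, a 2.0-fold higher number (0.30 log units; within the scatter) from compound 1 to compound 2 and a 3.0-fold higher number (0.48 log units; beyond the scatter) from compound 3 to compound 4, 1.5-fold (0.18 log units) apart, within the scatter of two such steps. For the compounds shown here, with only two pairs of compounds, this shows agreement on these two cores alone and does not show that a further core would behave alike, nor why the number rises.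

Only chloro and nitro appear at this place on the aromatic ring. Going by these compounds, what an amine or a carboxylic acid there would do remains open.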